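A few compounds are considered here, and "the series" means these few. Any claim that something is new, unique, unknown or untested is made for them only; others in the source may bear on it.

Measured so far in a functional assay on B16-F10 cells (Mus musculus); a lower number here means that less compound is needed, a higher number that more compound is needed for the effect:
compound 1 `Cc1nn(C[C@H]2CO[C@H](CO)O2)c(=O)[nH]c1=O`: > 100000 nM
compound 2 `Nc1ncn(C[C@H]2CO[C@@H](CO)O2)c(=O)n1`: 60000 nM
compound 3 `Nc1ncn(C[C@@H]2CO[C@@H](CO)O2)c(=O)n1`: 80000 nM

The reading of compound 1 is > 100000 nM, which is a limit and not a number. The starting point of this step is therefore known only as the limit of > 100000 nM in this assay, at which 1 of the 3 values shown sits.

Compound 4 `Cc1nn(C[C@@H]2CO[C@@H](CO)O2)c(=O)[nH]c1=O` has not yet been measured. It is the mirror image of compound 1: the two compounds have the same atoms and bonds and differ only in configuration as drawn: 2 of 2 stereo elements differ (all stereocentres are inverted: mirror images); a stereocentre at a saturated ring carbon is drawn S in compound 1 and R in compound 4; a stereocentre at a saturated ring carbon is drawn S in compound 1 and R in compound 4. Nothing leaves and nothing enters, so the change lies in configuration alone.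

Going by the values given here, one measured step bears on this change: a 1.3-fold higher number from compound 2 to compound 3 (0.12 log units; within the scatter). For that pair the evidence is the fact that compounds 2 and 3 differ only in the configuration as drawn. It is only a partial guide, since one of two stereo elements differs there while both are inverted here, and compounds 2 and 3 do not share the core of compound 1.

With that single step inside the scatter, no step beyond the scatter is expected in this assay, and no direction can be favoured. A reading that is again only a limit would be no surprise. The expected size of the change is a number no higher from compound 1 to compound 4 (the limit leaves the size open). Compound 4 is estimated at 100000 nM, with an expected range from 40000 nM to 200000 nM.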

Compound 4, half-maximal effective concentration: > 100000 nM
Compound 4 ended at the assay's limit; the forecaster's own chance of this, stated with the estimate: 65%; the middle value sits exactly at the limit.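

Compound 4, like compound 1, ended at a limit of this assay and not at a number, so the step between these two mirror images cannot be read. The compounds shown leave open whether inverting both stereocentres changes the effect on these cells at all, since neither compound has a number here.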